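The source may report more compounds than this note shows. Statements on the series, on what has been measured and on what is new or still open speak of the compounds shown alone.

In a functional assay on the whole organism (Abdomen, strain Swiss) for inhibition, with Mus musculus as the target, with stated times of 30 min, 10 min and 5 min, at a dose of 40 mg/kg by the oral route (a lower number here means a weaker effect, a higher number a stronger effect of the compound at the dose given), the three measured compounds stand as follows:

compound 1 `CC(=O)c1cccn1CCCN1CCN(c2cccc(Cl)c2)CC1`: 54%;
compound 2 `COc1cccc(N2CCN(CCCn3cccc3C(C)=O)CC2)c1`: 52%;
compound 3 `O=c1occ(-c2ccccc2)n1CCCN1CCN(c2cccc(Cl)c2)CC1`: 38%.

Compound 1 and compound 2 differ in a single place: methoxy in place of chloro on an aromatic carbon. That change made a number 2 percentage points lower from compound 1 to compound 2 (within the scatter). Compound 3 gives the lowest of the three numbers in this assay; how its core differs from the core of compound 1 is not broken down here. Compound 4 `COc1cccc(N2CCN(CCCn3c(-c4ccccc4)coc3=O)CC2)c1` arises from compound 3 through the same change, (methoxy in place of chloro on an aromatic carbon), at a place described in the same words as before. Because the same change gave a number 2 percentage points lower from compound 1 to compound 2 (within the scatter), compound 4 is expected to show no change at the digits printed from compound 3 to compound 4 (within the scatter). Compound 4 is therefore estimated at 38% in this assay, within a range from 26% to 50%.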

Compound 4, a percentage reported as inhibition, in the whole organism at one dose (the size of the read-out at that dose, not a potency): 39%
Compound 4: the middle estimate sits 1 percentage points below what was measured; the measured number falls inside the stated range.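

In this assay, going from 3-chlorophenyl to 3-methoxyphenyl on the second core gave a number 1 percentage points higher from compound 3 to compound 4 (within the scatter), and the two steps can be set side by side: the same change on two cores in this assay, a number 2 percentage points lower (within the scatter) from compound 1 to compound 2 and a number 1 percentage points higher (within the scatter) from compound 3 to compound 4, 3 percentage points apart, within the scatter of two such steps

On these two cores, then, the change carries over with no step beyond the scatter and no difference between the cores that the data can resolve. Among these compounds, this rests on only two pairs at one oral dose, and it shows neither that the change would behave alike on other cores nor anything about potency.

The compounds shown leave open whether a nitrile or an amine on that aromatic carbon would give a step beyond the scatter. They also leave open whether a longer chain would alter how the change carries over.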